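Hydrazone series, whole-animal dose, aryl substituent swaps

A few compounds are considered here, and "the series" means these few. Any claim that something is new, unique, unknown or untested is made for them only; others in the source may bear on it.

Compound 3 `Cc1cc(C)cc(NN=C2CCC(C)n3c2ncc(C(=O)O)c3=O)c1` carries the 3,5-dimethylphenyl group. In a functional assay on the whole organism with Rattus norvegicus as the target (a higher number here means that more compound is needed for the effect, a lower number that less compound is needed), compound 3 gives only a limit of the assay, > 320 umol/kg. Compound 1 `Cc1cccc(NN=C2CCC(C)n3c2ncc(C(=O)O)c3=O)c1C` also gives only a limit in this assay, > 100 umol/kg. Compound 2 `Cc1ccc(NN=C2CCC(C)n3c2ncc(C(=O)O)c3=O)cc1C` likewise gives only a limit in this assay, > 100 umol/kg. Compound 3 therefore stands at a limit, and the two other values shown are limits as well, so no order among the three can be drawn. The steps between them, a step that the two limits leave unreadable from compound 1 to compound 2, a step that the two limits leave unreadable from compound 1 to compound 3 and a step that the two limits leave unreadable from compound 2 to compound 3, carry no readable size. Two of the three values sit at the limit of > 100 umol/kg in this assay, at which 2 of the 3 values shown sit, and one at the limit of > 320 umol/kg in this assay, at which 1 of the 3 values shown sits.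

Compound 4 `CC1CCC(=NNc2ccc(Cl)c(Cl)c2)c2ncc(C(=O)O)c(=O)n21` is still to be measured in this assay. The change from compound 3 is 3,4-dichlorophenyl in place of 3,5-dimethylphenyl on an amine nitrogen. Within the data shown here, the measured steps that bear on an aryl substituent swap are the three above, and none gives a readable size, so no direction can be drawn from them; with every value so far a limit, the expectation is that compound 4 will again sit at or beyond the limit rather than show a step within the readable range. Compound 4 is expected at 250 umol/kg, with a range of 60 umol/kg to 1000 umol/kg. The expected step is an at least 1.2-fold lower number from compound 3 to compound 4 (0.10 log units; that floor lies within the scatter).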

Compound 4, dose for 50% inhibition: > 100 umol/kg
Compound 4: a limit, no number; the forecaster's own chance of this, stated with the estimate: 75%; the middle value does not contradict the limit.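

In this assay compound 4 gives only a limit, > 100 umol/kg. Compound 1, compound 2 and compound 3 also stand at limits, so the steps from each of them to compound 4 cannot be read. The compounds shown leave open how these four aryl groups rank and whether any of them gives a measurable dose.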